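Anilino substitution in a chlorinated diaminopyrimidine growth-inhibitor series

A few compounds are considered here, and "the series" means these few. Any claim that something is new, unique, unknown or untested is made for them only; others in the source may bear on it.

Measured so far:
compound 1 `Cc1ccccc1Nc1nc(Nc2ccc(N3CCN(C)CC3)cn2)ncc1Cl` — 7470 nM
compound 2 `CCN1CCN(c2ccc(Nc3ncc(Cl)c(Nc4ccccc4C)n3)nc2)CC1` — > 100000 nM (a limit)

Among the measured compounds shown here, compound 1 gives 7470 nM in a functional assay on MDA-MB-231 cells (Homo sapiens) for inhibition, read by CCK-8 assay, with a stated time of 48 h (a lower number here means a stronger inhibitor of growth, a higher number a weaker inhibitor of growth), the only finite number in the set. Compound 2 reaches only the limit of > 100000 nM in this assay, at which 1 of the 2 values shown sits, in this assay. For the measured compounds named here, the one measured step, an at least 13-fold higher number from compound 1 to compound 2 (1.12 log units; beyond the scatter), concerns the methyl in place of hydrogen on a saturated chain carbon bound to an amine nitrogen in a ring and leaves the anilino side of the shared core untouched.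

Compound 3 `COc1cccc(CNc2nc(Nc3ccc(N4CCN(C)CC4)cn3)ncc2Cl)c1` differs from compound 1 at that other side: 3-methoxybenzyl in place of 2-methylphenyl on a nitrogen on an aromatic ring. Going by the values given here, no measured step touches this position, so the expectation rests on compound 1 alone, with the step from compound 1 to compound 2 showing only that this series is sensitive to small changes. For compound 3 the expected step is a 2.0-fold higher number from compound 1 to compound 3 (0.30 log units; within the scatter), in either direction or none beyond the scatter. Compound 3 is estimated at 15000 nM (range 4000 nM to 60000 nM) in this assay.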

Compound 3, concentration for 50% growth inhibition: 20300 nM
Compound 3: the middle estimate sits 1.4-fold (0.13 log units) below what was measured; low and high end bracket the measured number.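

The change from 2-methylphenyl to 3-methoxybenzyl on a nitrogen on an aromatic ring gives a 2.7-fold higher number from compound 1 to compound 3 (0.43 log units; beyond the scatter) in this assay, so the number responds to this side of the shared core as well. Compound 3 still gives a finite value, which makes this exchange readable as a measured step. Compound 2 carries only a limit, not a number: the limit of > 100000 nM in this assay, at which 1 of the 3 values shown sits.

The exchange alters both the link to the aromatic ring and the substituent on it, and the compounds shown do not separate these two parts. Whether plain benzyl would account for the step remains open, as does the effect of an amine or a carboxylic acid on that ring.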